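Swapping Trifluoromethyl for Fluoro: What to Expect

The source may hold more compounds than are shown below. What is called first, only, known or untested is meant among the compounds shown, and "the series" means these compounds.

Of the compounds shown here, two built on one shared core have been tested in a functional assay on OVCAR cells (Homo sapiens) for inhibition, read by MTT assay, with a stated time of 48 h; on this read-out lower numbers stand for stronger inhibition of growth and higher numbers for weaker inhibition of growth. Compound 1 `COc1ccc(-c2cc(-c3ccccc3)n[nH]2)cc1`, which carries a hydrogen on the aromatic carbon in question, gives 9900 nM in this assay. Compound 2 `COc1ccc(-c2cc(-c3ccc(C(F)(F)F)cc3)n[nH]2)cc1`, which carries a trifluoromethyl there, gives 22800 nM, the highest of the two numbers. For the measured compounds named here, the only measured step, a 2.3-fold higher number from compound 1 to compound 2 (0.36 log units; beyond the scatter), is the one change that bears on the next compound. Compound 3 `COc1ccc(-c2cc(-c3ccc(F)cc3)n[nH]2)cc1` differs from compound 2 by fluoro in place of trifluoromethyl on an aromatic carbon. A partial return toward the number of compound 1, 9900 nM, is expected, since the step of a 2.3-fold higher number from compound 1 to compound 2 (0.36 log units; beyond the scatter) introduced the very group that is now largely removed. Compound 3 is therefore expected to give about 12000 nM in this assay, within a range of 5000 nM to 30000 nM. That corresponds to an expected step of a 1.9-fold lower number from compound 2 to compound 3 (0.28 log units; within the scatter).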

Compound 3, concentration for 50% growth inhibition: 14000 nM
The estimate for compound 3 lay 1.2-fold (0.07 log units) below the measured number; the range from low to high includes it.
By their numbers in this assay, from the lowest: compounds 1, 3 and 2 (each within the scatter of the next, the first and the last beyond it).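

At this place on the six-membered aromatic ring, fluoro in place of trifluoromethyl gives a 1.6-fold lower number from compound 2 to compound 3 (0.21 log units; within the scatter), while fluoro in place of hydrogen gives a 1.4-fold higher number from compound 1 to compound 3 (0.15 log units; within the scatter), so in this assay compound 3 cannot be told apart from either compound 2 or compound 1. Only the hydrogen of compound 1 and the trifluoromethyl of compound 2 are separated by more than the usual scatter, which makes this position sensitive only modestly, as far as these compounds show. Nothing available gives a reason for these numbers. As far as these compounds go, it remains open whether an amine or a carboxylic acid at this position would move the number further, and in which direction. Whether any group here could bring growth inhibition much stronger than that of compound 1 is also unanswered.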